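A few compounds are considered here, and "the series" means these few. Any claim that something is new, unique, unknown or untested is made for them only; others in the source may bear on it.

Measured so far:
compound 1, `CC(C)(C)NC(=O)N1CC1C#N`, giving 180000 nM in a functional assay on WiDr cells (Homo sapiens) for inhibition; a higher number here means a weaker inhibitor, a lower number a stronger inhibitor;
compound 2, `CCOC(=O)c1ccc(NC(=O)N2CC2C#N)cc1`, giving 2500 nM in this assay.

Among the compounds with values here, compound 2 holds the lowest of the two numbers in this assay; compound 1 is its only neighbour, and the gap between them lies well beyond the scatter. The next compound, compound 3, `N#CC1CN1C(=O)Nc1ccc(C(F)(F)F)cc1`, is reached from compound 2 by one change: trifluoromethyl in place of ethoxycarbonyl on an aromatic carbon. Within the data shown here, no pair of measured compounds shows a step of this kind, so its size cannot be read off the numbers at hand. Among the measured compounds shown here, both groups occupy the same position on the ring, and nothing among the measured compounds argues for a large move in either direction; a step within the scatter, or at most a modest one, is expected. Compound 3 is therefore estimated to give 2000 nM in this assay, with a likely range from 600 nM to 7000 nM. For compound 3 this means an expected step of a 1.3-fold lower number from compound 2 to compound 3 (0.10 log units; within the scatter).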

Compound 3, half-maximal inhibitory concentration: 1300 nM
Beside the measured number, compound 3's estimate is 1.5-fold (0.19 log units) above it; the measured number falls inside the stated range.
By their numbers in this assay, from the lowest: compounds 3 and 2 (each within the scatter of the next); then compound 1.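

The change from ethoxycarbonyl to trifluoromethyl on this aromatic carbon gives a 1.9-fold lower number from compound 2 to compound 3 (0.28 log units; within the scatter) in this assay. Within the data shown here, this is the first single-place comparison, and it shows that this position accepts two quite different groups without a change beyond the scatter. The group with two hydrogen-bond acceptors can give way to one with none, so in this pair those acceptors are not needed to keep the number in this range, and no measurement at hand explains the result.

Going by these compounds, it remains open whether other groups at this position, such as an amine, a carboxylic acid or a longer chain, would stay within this range. One pair also cannot show how much the number depends on the nitrile, which every compound shown carries.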